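The source may report more compounds than this note shows. Statements on the series, on what has been measured and on what is new or still open speak of the compounds shown alone.

Measured so far in a functional assay (spleen, spleen) for activation, with Mus musculus as the target; on this read-out higher numbers stand for an effect only at larger amounts of compound and lower numbers for an effect already at smaller amounts:
- compound 1 `CCNc1nc(N)c2nc(O)n(Cc3ccccc3)c2n1`: 1 uM
- compound 2 `CSc1nc(N)c2nc(O)n(Cc3ccccc3)c2n1`: 0.1 uM
- compound 3 `CCCNc1nc(N)c2nc(O)n(Cc3ccccc3)c2n1`: 0.1 uM

Compound 3 is level with compound 2 at the digits shown, and together they carry the lowest numbers of the three; compound 1 lies apart, with a 10-fold lower number from compound 1 to compound 3 (1.00 log units; beyond the scatter).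

Compound 4 `CCSc1nc(N)c2nc(O)n(Cc3ccccc3)c2n1` is not yet measured. It differs from compound 3 as follows: ethylsulfanyl in place of propylamino on an aromatic carbon

Among the compounds with values here, two measured steps bear on this. Swapping amino for sulfanyl at this carbon gave a 10-fold lower number from compound 1 to compound 2 (1.00 log units; beyond the scatter), and the reverse swap at one carbon longer gave no change at the digits printed from compound 2 to compound 3 (within the scatter), so the two side chains appear interchangeable at this length. Lengthening the chain gave a 10-fold lower number from compound 1 to compound 3 (1.00 log units; beyond the scatter). Compound 4 is the sulfanyl chain of compound 2 lengthened by one carbon; a step of no size beyond the scatter, or a slight move to lower numbers, is therefore expected in this assay, as a 1.3-fold lower number from compound 3 to compound 4 (0.10 log units; within the scatter).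

For compound 4 the estimated value in this assay is 0.08 uM, expected between 0.02 uM and 0.3 uM.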

Compound 4, minimum effective concentration: 0.1 uM
Beside the measured number, compound 4's estimate is 1.3-fold (0.10 log units) below it, within the range that was stated.
By their numbers in this assay, from the lowest: compounds 2, 3 and 4 (each within the scatter of the next); then compound 1.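

In this assay, ethylsulfanyl and propylamino on this aromatic carbon cannot be told apart, with no change at the digits printed from compound 3 to compound 4 (within the scatter), and the sulfanyl chain shows no response to one more carbon, with no change at the digits printed from compound 2 to compound 4 (within the scatter). At the same chain length, ethylsulfanyl in place of ethylamino gives a 10-fold lower number from compound 1 to compound 4 (1.00 log units; beyond the scatter), so compound 1 is the only one of the four that stands apart. The gain from the added chain carbon therefore appears with the amino link and not with the sulfanyl link: the same change on two cores in this assay, a 10-fold lower number (1.00 log units; beyond the scatter) from compound 1 to compound 3 and no change at the digits printed (within the scatter) from compound 2 to compound 4, 10-fold (1.00 log units) apart, beyond the scatter of two such steps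

As far as these compounds go, it remains open whether the level shared by compound 2, compound 3 and compound 4 holds for longer chains such as butylsulfanyl or butylamino. From the compounds shown here alone, the response to an oxygen link at this carbon, as in ethoxy or propoxy, also remains open.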